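Moving from compound 3 to compound 4 on the thioether chain

The source may hold more compounds than are shown below. What is called first, only, known or untested is meant among the compounds shown, and "the series" means these compounds.

Compound 3 `O=C1CCC(CSc2nc(-c3ccccc3)c(-c3ccccc3)[nH]2)N1` gives 360 nM in an assay on microsomes from liver for inhibition of sterol O-acyltransferase 1 (Rattus norvegicus) (on this read-out higher numbers stand for weaker inhibition and lower numbers for stronger inhibition), the highest of the three numbers shown. Compound 1 `C[C@]1(O)CC(=O)OC(CSc2nc(-c3ccccc3)c(-c3ccccc3)[nH]2)C1` gives 140 nM and compound 2 `CO[C@H]1C[C@H](O)C[C@@H](CSc2nc(-c3ccccc3)c(-c3ccccc3)[nH]2)O1` gives 90 nM; the steps of a 2.6-fold higher number from compound 1 to compound 3 (0.41 log units; beyond the scatter) and a 4.0-fold higher number from compound 2 to compound 3 (0.60 log units; beyond the scatter) show that the 5-oxopyrrolidin-2-yl group raised the number relative to either earlier ring. Compound 4 `c1ccc(-c2nc(SCCC3OCCCO3)[nH]c2-c2ccccc2)cc1` carries a group of 7 heavy atoms (5 carbon, 2 oxygen; one six-membered non-aromatic ring with 2 hetero atoms) in place of a group of 6 heavy atoms (4 carbon, 1 nitrogen, 1 oxygen; one five-membered non-aromatic ring with 1 hetero atom), on a saturated chain carbon bound to a sulfur. This change again places a six-membered ring on the saturated chain carbon bound to the sulfur, and both measured steps toward compound 3 moved upward, so a modestly lower number is expected for compound 4 in this assay. Compound 4 is therefore estimated at 150 nM, between 60 nM and 400 nM, a step of a 2.4-fold lower number from compound 3 to compound 4 (0.38 log units; beyond the scatter).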

Compound 4, half-maximal inhibitory concentration: 730 nM
For compound 4 the middle estimate is 4.9-fold (0.69 log units) below the measured one; the whole stated range lies below it.
By their numbers in this assay, from the lowest: compounds 2 and 1 (each within the scatter of the next); then compound 3; then compound 4.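

In this assay, a six-membered ring on a saturated chain carbon bound to a sulfur did not by itself keep the number low: the ring with 2 hetero atoms and 0 hydrogen-bond donors gave a higher number than the 5-oxopyrrolidin-2-yl group (a 2.0-fold higher number from compound 3 to compound 4 (0.31 log units; beyond the scatter)). The gaps to the earlier six-membered rings were wider (an 8.1-fold higher number from compound 2 to compound 4 (0.91 log units; beyond the scatter); a 5.2-fold higher number from compound 1 to compound 4 (0.72 log units; beyond the scatter)), so ring size alone does not order these four compounds. No measured evidence bears on the reason for this result. The compounds shown leave open how an amine or a carboxylic acid would read at this place.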